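A few compounds are considered here, and "the series" means these few. Any claim that something is new, unique, unknown or untested is made for them only; others in the source may bear on it.

Values in a functional assay on MDA-MB-231 cells (Homo sapiens) for inhibition, read by MTT assay; on this read-out lower numbers stand for stronger inhibition of growth and higher numbers for weaker inhibition of growth:
- compound 1 `CC1=C(/C=C/C(C)=C/C=C/C(C)=C\C(=O)Nc2ccccc2)C(C)(C)CCC1n1ccnc1` - 1740 nM
- compound 2 `CC1=C(/C=C/C(C)=C/C=C/C(C)=C\C(=O)NCc2cccc(F)c2)C(C)(C)CCC1n1ccnc1` - 1650 nM
- compound 3 `CC1=C(/C=C/C(C)=C/C=C/C(C)=C\C(=O)Nc2ccc(F)cc2)C(C)(C)CCC1n1ccnc1` - 4950 nM
- compound 4 `CC1=C(/C=C/C(C)=C/C=C/C(C)=C\C(=O)NCc2ccc(O)cc2)C(C)(C)CCC1n1ccnc1` - not yet measured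

Compound 3 has the highest number of the three 4950 nM, so it inhibits growth least. In compound 4, 4-hydroxybenzyl replaces 4-fluorophenyl on an amide-type nitrogen (4-hydroxybenzyl in place of 4-fluorophenyl on an amide-type nitrogen). The closest guide is the reverse kind of swap, a 3.0-fold higher number from compound 2 to compound 3 (0.48 log units; beyond the scatter), where a benzyl group gave way to a fluorophenyl group. Adding the fluoro alone gave a 2.8-fold higher number from compound 1 to compound 3 (0.45 log units; beyond the scatter), while a 1.1-fold lower number from compound 1 to compound 2 (0.02 log units; within the scatter). Within the data shown here, no measured compound carries a hydroxy group, so that part remains untested. A modest drop is therefore expected, a 2.5-fold lower number from compound 3 to compound 4 (0.39 log units; beyond the scatter). The estimated value for compound 4 is 2000 nM, with an expected range of 800 nM to 5000 nM.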

Compound 4, concentration for 50% growth inhibition: 2230 nM
Estimate against measurement, compound 4: 1.1-fold (0.05 log units) below, and the stated range covers the measured number.
By their numbers in this assay, from the lowest: compounds 2, 1 and 4 (each within the scatter of the next); then compound 3.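

Replacing 4-fluorophenyl with 4-hydroxybenzyl on the amide-type nitrogen gives a 2.2-fold lower number from compound 3 to compound 4 (0.35 log units; beyond the scatter), which leaves compound 3 as the weakest of the four. The new group also fits this position about as well as phenyl or 3-fluorobenzyl: a 1.3-fold higher number from compound 1 to compound 4 (0.11 log units; within the scatter) and a 1.4-fold higher number from compound 2 to compound 4 (0.13 log units; within the scatter) both lie within the scatter. No measurement shown explains these differences.

Going by these compounds, the swap changes both the ring substituent and the link to the nitrogen, so their separate contributions remain unknown. On these data alone, how an amine, a carboxylic acid or a longer chain would behave here also remains open.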